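A few compounds are considered here, and "the series" means these few. Any claim that something is new, unique, unknown or untested is made for them only; others in the source may bear on it.

In an in vitro ADME assay on microsomes from liver (Homo sapiens) for metabolic stability, read by LC-MS (on this read-out lower numbers stand for a shorter-lived compound and higher numbers for a longer-lived compound), compound 1 `CN/C(=N\C1=NC(=O)C(=O)N1C(C)C)Nc1ccc(Cl)c(Cl)c1` gives > 1 h, which is a limit of the assay and not a number. Compound 2 `CC(C)N/C(=N\C1=NC(=O)C(=O)N1C(C)C)Nc1ccc(Cl)c(Cl)c1` gives > 1 h, also a limit. Compound 3 `CC(C)N1C(=O)C(=O)N=C1/N=C(\NCC(C)(C)C)Nc1ccc(Cl)c(Cl)c1` gives > 1 h, again a limit. The whole record so far is thus (the limit of > 1 h in this assay, at which 3 of the 3 values shown sit), and compound 1 has no number from which to count.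

The next compound, compound 4 `CC(C)N1C(=O)C(=O)N=C1/N=C(\NCCN1CCCC1)Nc1ccc(Cl)c(Cl)c1`, differs from compound 1 by (pyrrolidin-1-yl)methyl in place of hydrogen on a saturated chain carbon bound to an amine nitrogen. Put another way, the change is methyl to 2-(pyrrolidin-1-yl)ethyl. The closest measured change, tert-butyl in place of hydrogen on a saturated chain carbon bound to an amine nitrogen, is a step that the two limits leave unreadable from compound 1 to compound 3. Isopropyl in place of methyl on an amine nitrogen is a step that the two limits leave unreadable from compound 1 to compound 2, and neopentyl in place of isopropyl on an amine nitrogen is a step that the two limits leave unreadable from compound 2 to compound 3. None of these steps has a readable size, so they supply neither a size nor a direction for the new change, and no step beyond the scatter is expected on their evidence. The expected change is a step that the limit leaves unreadable from compound 1 to compound 4, and the assay may well report a limit again. Compound 4 is expected at an estimated 1.5 h, with an estimated range from 0.5 h to 4 h.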

Compound 4, half-life: 0.886 h
Beside the measured number, compound 4's estimate is 1.7-fold (0.23 log units) above it; the measured number falls inside the stated range.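

In this assay, for the compounds shown here, compound 4 is the first compound here to give a number and not a limit, so 2-(pyrrolidin-1-yl)ethyl on an amine nitrogen brings the first steps at this position with any readable content, while the steps among compound 1, compound 2 and compound 3 cannot be read. The new result reads as an at least 1.1-fold lower number from compound 1 to compound 4 (0.05 log units; that floor lies within the scatter), as an at least 1.1-fold lower number from compound 3 to compound 4 (0.05 log units; that floor lies within the scatter) and as an at least 1.1-fold lower number from compound 2 to compound 4 (0.05 log units; that floor lies within the scatter), so all three steps point the same way, but each printed floor stays within the usual scatter and does not establish a real difference. Each of these steps has a limit at one end, so only a floor can be given for its size: the limit of > 1 h in this assay, at which 3 of the 4 values shown sit.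

From the compounds shown here alone, how far compound 1, compound 2 and compound 3 lie past their shared limit stays open, and with it the true size of all three steps. Also open, going by these compounds, is whether the number of compound 4 goes with the pyrrolidine ring itself or with the chain that carries it, a question that a piperidine, a morpholine or a dimethylamino group at the end of the same ethyl chain would address.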